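A thiophen-3-yl to 3,5-dimethoxyphenyl step, before measurement

The source may hold more compounds than are shown below. What is called first, only, known or untested is meant among the compounds shown, and "the series" means these compounds.

Three measured compounds share one core and differ only in the group carried on an aromatic carbon of the outer ring. Compound 1 `CC(C)N(Cc1cccc(OCCCCCC(=O)O)c1)C(=O)c1ccccc1` carries a hydrogen there, compound 2 `CC(=O)Nc1cccc(-c2ccc(C(=O)N(Cc3cccc(OCCCCCC(=O)O)c3)C(C)C)cc2)c1` a 3-acetamidophenyl, and compound 3 `CC(C)N(Cc1cccc(OCCCCCC(=O)O)c1)C(=O)c1ccc(-c2ccsc2)cc1` a thiophen-3-yl. In an ADME assay on Raji cells (Homo sapiens) for cytotoxicity, read by CellTiter-Glo and resazurin assay, with a stated time of 72 h (on this read-out higher numbers stand for an effect only at larger amounts of compound and lower numbers for an effect already at smaller amounts), compound 1 gives > 26000 nM, which is a limit of the assay rather than a number. Compound 2 likewise gives > 26000 nM, again a limit. Compound 3 stands at > 26000 nM, once more a limit and not a number, so its true position is not known. All three values sit at the limit of > 26000 nM in this assay, at which 3 of the 3 values shown sit.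

The steps between these compounds are consequently unreadable: a step that the two limits leave unreadable from compound 1 to compound 2, a step that the two limits leave unreadable from compound 1 to compound 3 and a step that the two limits leave unreadable from compound 2 to compound 3. No size or direction can be taken from any of them.

Compound 4 `COc1cc(OC)cc(-c2ccc(C(=O)N(Cc3cccc(OCCCCCC(=O)O)c3)C(C)C)cc2)c1` is the next change, namely (3,5-dimethoxyphenyl in place of thiophen-3-yl on an aromatic carbon). None of the three measured steps can size this change; each of them ends at the limit. The only expectation available is that compound 4 behaves like compound 3, and the step is estimated as a step that the limit leaves unreadable from compound 3 to compound 4. Compound 4 is expected at roughly 40000 nM, within a range of 15000 nM to 150000 nM, most likely reported again only as a limit.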

Compound 4, half-maximal effective concentration: > 26000 nM
Compound 4 gave a limit, no number; the forecaster's own chance of this, stated with the estimate: 85%; the middle value is on the limit's open side.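

In this assay compound 4 gives > 26000 nM and this is a limit, not a number. For the compounds shown here, no step between compound 4 and compound 1, compound 2 or compound 3 can be read, because all of them end at the same limit: the limit of > 26000 nM in this assay, at which 4 of the 4 values shown sit. The compounds shown leave open how far apart their true values lie, and at what concentration any of them would affect these cells.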